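Swapping an aromatic ring for a saturated one

The source may hold more compounds than are shown below. What is called first, only, known or untested is meant among the compounds shown, and "the series" means these compounds.

Measured so far:
- compound 1 `COc1cc(-c2cn(C(=O)NCCCCc3ccccc3)c(=O)o2)ccc1F` — 80 nM
- compound 2 `O=C(NCCCCc1ccccc1)n1cc(-c2ccncc2)oc1=O` — 18 nM

Within the data shown here, in an assay on isolated protein for inhibition of acid ceramidase (Homo sapiens), read by LC-MS, with a stated time of 1 h (on this read-out higher numbers stand for weaker inhibition and lower numbers for stronger inhibition), compound 2 gives the lowest of the two numbers; its nearest neighbour is compound 1, and the single measured step, a 4.4-fold lower number from compound 1 to compound 2 (0.65 log units; beyond the scatter), separates them. Compound 3 `CN1CCC(c2cn(C(=O)NCCCCc3ccccc3)c(=O)o2)CC1` has 1-methylpiperidin-4-yl in place of pyridin-4-yl on an aromatic carbon. Among the measured compounds shown here, no measured step covers a change from an aromatic to a non-aromatic ring at this place, so that step offers only a rough scale of what one change here can do. The number for compound 3 is expected to come out somewhat higher than that of compound 2, with wide uncertainty, giving a 3.3-fold higher number from compound 2 to compound 3 (0.52 log units; beyond the scatter). The estimate for compound 3 is 60 nM, between 15 nM and 300 nM.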

Compound 3, half-maximal inhibitory concentration: 1400 nM
Compound 3: the middle estimate sits 23-fold (1.37 log units) below what was measured; measured number outside the range, above it.
By their numbers in this assay, from the lowest: compound 2; then compound 1; then compound 3.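

In this assay, putting 1-methylpiperidin-4-yl in place of pyridin-4-yl gives a 78-fold higher number from compound 2 to compound 3 (1.89 log units; beyond the scatter), and putting it in place of 4-fluoro-3-methoxyphenyl gives an 18-fold higher number from compound 1 to compound 3 (1.24 log units; beyond the scatter). Both steps are larger than the earlier swap between two aromatic rings, so at this position the choice between these aromatic rings and this non-aromatic ring matters more than the choice between the two aromatic rings. Nothing measured here gives a reason for this gap. Going by these compounds, it remains open whether a cyclohexyl ring, or a piperidin-4-yl ring without the methyl, would give a number closer to compound 2 or to compound 3.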